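Pyridin-4-yl in Place of Pyridin-3-yl

The source may hold more compounds than are shown below. What is called first, only, known or untested is meant among the compounds shown, and "the series" means these compounds.

In a functional assay on SGC-7901 cells (Homo sapiens) for cytotoxicity, read by MTT assay, with a stated time of 48 h (on this read-out lower numbers stand for stronger inhibition and higher numbers for weaker inhibition), compound 2 `Cc1ncc([N+](=O)[O-])n1CCSc1nnc(-c2cccnc2)o1` gives 31600 nM and compound 1 `Cc1cccc(-c2nnc(SCCn3c([N+](=O)[O-])cnc3C)o2)c1O` gives 35900 nM and the two stand level within the scatter. Among the compounds with values here, the only measured step is a 1.1-fold lower number from compound 1 to compound 2 (0.06 log units; within the scatter) and it comes from pyridin-3-yl taking the place of 2-hydroxy-3-methylphenyl on the same aromatic carbon that changes next. Compound 3 `Cc1ncc([N+](=O)[O-])n1CCSc1nnc(-c2ccncc2)o1` differs from compound 2 by pyridin-4-yl in place of pyridin-3-yl on an aromatic carbon with pyridin-4-yl in place of pyridin-3-yl on an aromatic carbon of a five-membered aromatic ring with 2 nitrogen and 1 oxygen. Within the data shown here, with a 1.1-fold lower number from compound 1 to compound 2 (0.06 log units; within the scatter) as the sole guide, no step beyond the scatter is expected in this assay and no direction can be favoured. The expected step is a 1.1-fold lower number from compound 2 to compound 3 (0.02 log units; within the scatter) on this single comparison. Compound 3 is estimated at 30000 nM with an expected range of 12000 nM to 70000 nM until its measurement is known.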

Compound 3, half-maximal inhibitory concentration: 15900 nM
Compound 3: the middle estimate sits 1.9-fold (0.28 log units) above what was measured, and the stated range covers the measured number.
By their numbers in this assay, from the lowest: compounds 3, 2 and 1 (each within the scatter of the next, the first and the last beyond it).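

Exchanging pyridin-3-yl for pyridin-4-yl, the same atoms joined differently, gives a 2.0-fold lower number from compound 2 to compound 3 (0.30 log units; within the scatter) and so stays within the scatter, which means that this assay does not separate these two pyridine attachments on this carbon of the five-membered aromatic ring. Set against the 2-hydroxy-3-methylphenyl group, however, pyridin-4-yl gives a 2.3-fold lower number from compound 1 to compound 3 (0.35 log units; beyond the scatter), the first step at this position to pass beyond the scatter, though only modestly. Nothing available here bears on what lies behind this difference.

The compounds shown carry only aromatic rings at this carbon, so it remains open how pyridin-2-yl, an unsubstituted phenyl or a phenyl ring bearing a carboxylic acid would read here. As far as these compounds go, an amine such as morpholine in the same place also remains open.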